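A few compounds are considered here, and "the series" means these few. Any claim that something is new, unique, unknown or untested is made for them only; others in the source may bear on it.

Two measured compounds share a core. Compound 1 `NC(=O)c1cc(Cl)c2c(Cl)c(C#CC3COCCO3)n([C@H]3CCCNC3)c2n1` carries a dioxanyl-ethynyl group and, in a functional assay on KG-1 cells (Homo sapiens) for antiproliferative activity (a lower number here means that less compound is needed, a higher number that more compound is needed for the effect), compound 1 gives 77 nM; 203 nM (2 entries) across its repeat measurements (the several entries of compound 1 in this assay, 77 nM; 203 nM (2 entries)). Going by the values given here, compound 2 `CN1CC(C#Cc2c(Cl)c3c(Cl)cc(C(N)=O)nc3n2[C@H]2CCCNC2)CC1=O` carries instead a 2-(1-methyl-5-oxopyrrolidin-3-yl)ethynyl group; in this assay compound 2 gives 155 nM, the only number recorded for it, alongside a further entry that yielded no single number. The two compounds therefore sit close together, and neither can be placed above the other.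

Compound 3 `CC(C)(O)C#Cc1c(Cl)c2c(Cl)cc(C(N)=O)nc2n1[C@H]1CCCNC1` is not yet measured. It differs from compound 2 in one place: 1-hydroxy-1-methylethyl in place of 1-methyl-5-oxopyrrolidin-3-yl on a triple-bonded carbon. The ring bearing a carbonyl leaves and a small alcohol enters, while the ethynyl linker and the rest of the core stay untouched.

Since the two measured alkynyl substituents, a cyclic ether and a lactam, give values within reach of each other, the step from compound 2 to compound 3 is expected to be small, at most a modest improvement or none beyond the scatter, expressed as a 1.3-fold lower number from compound 2 to compound 3 (0.11 log units; within the scatter). Compound 3 is accordingly estimated at 120 nM, with a range from 40 nM to 400 nM.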

Compound 3, half-maximal effective concentration: 302 nM
For compound 3 the middle estimate is 2.5-fold (0.40 log units) below the measured one; the measured number falls inside the stated range.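

In this assay, exchanging the 1-methyl-5-oxopyrrolidin-3-yl ring on the triple-bonded carbon for the open 1-hydroxy-1-methylethyl group gives a 1.9-fold higher number from compound 2 to compound 3 (0.29 log units; within the scatter). Compounds 1 and 2 both carry a ring at this place, so compound 3 adds the first case without one: a group with no ring, fewer heavy atoms and a hydrogen-bond donor that the lactam lacks still gives a value that cannot be separated from that of compound 2, so this ring is not shown to be needed for the effect on these cells. The size of this step also has to be read against the spread of repeat measurements for a single compound: the several entries of compound 1 in this assay, 77 nM; 203 nM (2 entries)

As far as these compounds go, what a tert-butyl group, which keeps the branched shape without the hydroxyl, or a dimethylamino-bearing chain would give on this triple-bonded carbon remains open. The compounds shown therefore cannot tell whether the hydroxyl of compound 3 contributes to its value in this assay, or whether the alkyne substituent can be varied much further without a step beyond the scatter.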